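Ester series on the shared core: swap at the aroyl group

The compounds below may be only part of what the source reports. "The series", "measured", "known", "first", "only" and "open" are said of these compounds alone.

Measured so far:
compound 1, `CC1=CC[C@H](C(C)C)c2cc(C)c(OC(=O)c3ccc([N+](=O)[O-])cc3)cc21`: 67.8%
compound 2, `COc1cccc(C(=O)Oc2cc3c(C)ccc(C(C)C)c3cc2C)c1`: 35.2%
compound 3, `CC1=CC[C@H](C(C)C)c2cc(C)c(OC(=O)c3ccc(C(F)(F)F)cc3)cc21`: 6.4%

In a functional assay on HCT-15 cells (Homo sapiens) for antiproliferative activity, read by sulforhodamine B assay, with a stated time of 48 h, tested at 50 uM (on this read-out lower numbers stand for less inhibition and higher numbers for more inhibition at the one concentration tested (going by the name of the read-out)), compound 1 gives 67.8%, the highest of the three numbers; compound 2 sits nearer to it and compound 3 furthest from it. Compound 2 differs from compound 1 in more than one place, so its value is only set alongside as it stands. Among the measured compounds shown here, the one single-point step available is a number 61.4 percentage points lower from compound 1 to compound 3 (beyond the scatter), which shows that exchanging the nitro on the aromatic ring costs most of the inhibition seen for compound 1.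

Compound 4, `CC1=CC[C@H](C(C)C)c2cc(C)c(OC(=O)c3cccc(Cl)c3)cc21`, is not yet measured in this assay. It differs from compound 1 by 3-chlorophenyl in place of 4-nitrophenyl on a carbonyl carbon. As in the step to compound 3, the nitro leaves; the ring that enters carries chlorine instead. For the measured compounds named here, the step from compound 1 to compound 3 is the only one bearing on this change, and it was large and downward, so a drop beyond the scatter is expected here too, though its size is uncertain with a single precedent. Compound 4 is therefore estimated at 20%, within 3% to 45%, an expected step of a number 47.8 percentage points lower from compound 1 to compound 4 (beyond the scatter).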

Compound 4, a percentage reported as inhibition, at one concentration (the size of the read-out at that concentration, not a potency): 5.3%
Compound 4: middle estimate off by 14.7 percentage points, on the high side; measured number inside the range.
By their numbers in this assay, from the lowest: compounds 4 and 3 (each within the scatter of the next); then compound 2; then compound 1.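

On the carbonyl carbon of the ester, a second replacement of 4-nitrophenyl also loses most of the inhibition: in this assay the change to 3-chlorophenyl gives a number 62.5 percentage points lower from compound 1 to compound 4 (beyond the scatter). The loss is therefore not peculiar to the trifluoromethyl ring, and compound 3 at 6.4% and compound 4 at 5.3% lie within the scatter of each other, so of these three esters only the 4-nitrophenyl ring of compound 1 keeps substantial inhibition. Nothing at hand accounts for this drop.

This step changes both the substituent and its place on the ring, so the two contributions cannot be separated. A 3-nitrophenyl and a 4-chlorophenyl ester would separate them, while a 4-aminophenyl ester would show whether a nitrogen group other than nitro can hold the inhibition.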